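A few compounds are considered here, and "the series" means these few. Any claim that something is new, unique, unknown or untested is made for them only; others in the source may bear on it.

Compound 1 `COc1cc(CC(O)(COCc2ccccc2)COCc2ccccc2)nc(OC)n1` gives in a functional assay on HepG2 cells (Homo sapiens) for antiproliferative activity, read by MTT assay, with a stated time of 72 h (on this read-out higher numbers stand for weaker inhibition and lower numbers for stronger inhibition), a limit of the assay, not a number: > 100000 nM.
Compound 2 `COc1cc(CC(COCc2ccccc2)COCc2ccccc2)nc(OC)n1` gives in this assay 300 nM.
Compound 3 `COc1cc(CC(O)COCc2ccccc2)nc(OC)n1` gives in this assay a limit of the assay, not a number: > 100000 nM.

Compound 3 thus sits at the limit of > 100000 nM in this assay, at which 2 of the 3 values shown sit, and only compound 2 carries a number. The step to compound 4 `COc1nc(CC(O)COCc2ccccc2)c(OC)c(OC)n1` changes the shared core: methoxy in place of hydrogen on an aromatic carbon. Among the measured compounds shown here, none of the measured steps touches the ring; they all concern the chain: an at least 330-fold lower number from compound 1 to compound 2 (2.52 log units; beyond the scatter) and an at least 330-fold higher number from compound 2 to compound 3 (2.52 log units; beyond the scatter), while a step that the two limits leave unreadable from compound 1 to compound 3. With nothing bearing on a change at the ring, no step beyond the scatter is expected from compound 3, and compound 4 is expected to give again a limit. Compound 4 is estimated at 100000 nM, between 30000 nM and 300000 nM. This expected outcome means a number no higher from compound 3 to compound 4 (the limit leaves the size open).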

Compound 4, half-maximal inhibitory concentration: > 100000 nM
Compound 4 ended at the assay's limit; the forecaster's own chance of this, stated with the estimate: 80%; the middle value sits exactly at the limit.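

Among the compounds shown here, compound 3 and compound 4 both end at a limit of the assay rather than a number, so no step between them can be read. The compounds shown leave open whether methoxy in place of hydrogen on this aromatic carbon changes the value at all.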